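Dienone series on gastric carcinoma cells: nitro to dichloro swap

A few compounds are considered here, and "the series" means these few. Any claim that something is new, unique, unknown or untested is made for them only; others in the source may bear on it.

Compound 1 `O=C(/C=C/c1cc([N+](=O)[O-])ccc1Cl)/C=C/c1ccccc1Oc1ncnc2ccc(Cl)cc12` stands highest of the two numbers in hand. In a functional assay on MGC-803 cells (Homo sapiens) for inhibition, read by MTT assay, with a stated time of 72 h, tested at 10 uM (a lower number here means less inhibition of growth, a higher number more inhibition of growth at the concentration tested), compound 1 gives 91.6%. Compound 2 `O=C(/C=C/c1ccc(Oc2ncnc3ccc(Cl)cc23)cc1)/C=C/c1ccc(Cl)c(Cl)c1` gives 50.5% in this assay, a number beyond the scatter below compound 1. Compound 3 `O=C(/C=C/c1ccccc1Oc1ncnc2ccc(Cl)cc12)/C=C/c1cccc(Cl)c1Cl` differs from compound 1 by 2,3-dichlorophenyl in place of 2-chloro-5-nitrophenyl on a double-bonded chain carbon bound to a double-bonded chain carbon. Within the data shown here, no single-change step between measured compounds exists to size this swap; the shared core is kept. A modest loss in this assay, possibly not beyond the scatter, is expected, and the step from compound 1 to compound 3 is estimated as a number 13.6 percentage points lower from compound 1 to compound 3 (beyond the scatter). Compound 3 is expected to give 78% in this assay, within 55% to 93%.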

Compound 3, percent growth inhibition at one concentration: 76.5%
Estimate against measurement, compound 3: 1.5 percentage points above, within the range that was stated.
By their numbers in this assay, from the lowest: compound 2; then compound 3; then compound 1.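

Among these compounds, at the position on a double-bonded chain carbon bound to a double-bonded chain carbon, the swap to 2,3-dichlorophenyl gives the first sized step for the series: in this assay it is a number 15.1 percentage points lower from compound 1 to compound 3 (beyond the scatter). Among the compounds shown here, the 2-chloro-5-nitrophenyl group is therefore not the only group here that allows substantial growth inhibition, as compound 3 still gives 76.5%, although the loss is beyond the scatter. No available evidence bears on the reason for this step.

Left open is how an amine or a carboxylic acid on this phenyl ring would perform at the same position. Going by these compounds, it also remains open how much of the step belongs to the nitro group and how much to the second chlorine.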